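Benzylsulfanyl anilides: chloro-to-fluoro swap, rat arterial read-out

The source may report more compounds than this note shows. Statements on the series, on what has been measured and on what is new or still open speak of the compounds shown alone.

Compound 1 `CC1=C(C(=O)Nc2ccc(Br)cc2)C(c2ccc(Cl)cc2Cl)N=C(SCc2ccc(Cl)cc2)N1` and compound 2 `CC1=C(C(=O)Nc2ccc(Br)cc2)C(c2ccc(Cl)cc2Cl)N=C(SCc2ccc(F)cc2)N1` share one core; compound 3 `CC1=C(C(=O)Nc2ccc([N+](=O)[O-])cc2)C(c2ccc(Br)cc2)N=C(SCc2ccc(Cl)cc2)N1` and compound 4 `CC1=C(C(=O)Nc2ccc([N+](=O)[O-])cc2)C(c2ccc(Br)cc2)N=C(SCc2ccc(F)cc2)N1` share another, and the difference between the two cores is not broken down here. In a functional assay on the whole organism (artery, strain albino) with Rattus norvegicus as the target, with a stated time of 60 min, at a dose of 10 mg/kg by the oral route (a lower number here means less inhibition, a higher number more inhibition at the dose given (going by the name of the read-out)), compound 1 gives 11.8% and compound 2 gives 16.9%. The change between them, (fluoro in place of chloro on an aromatic carbon), came with a step of a number 5.1 percentage points higher from compound 1 to compound 2 (within the scatter). In this assay compound 3 gives 10.8%; this number and that of compound 1 lie within the scatter of each other, as do those of compound 3 and compound 2, so no order among the three is claimed. Compound 4 carries the same change against compound 3 that compound 2 carries against compound 1: fluoro in place of chloro on an aromatic carbon. With one measured instance of this change, the step from compound 3 to compound 4 in this assay is expected to be small, about a number 5.2 percentage points higher from compound 3 to compound 4 (within the scatter), which rests on compound 1 and compound 2 having shown a number 5.1 percentage points higher from compound 1 to compound 2 (within the scatter). For compound 4 in this assay the estimate is 16%, with a likely range from 6% to 26%.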

Compound 4, a percentage reported as inhibition, in the whole organism at one dose (the size of the read-out at that dose, not a potency): 9.7%
Compound 4: middle estimate off by 6.3 percentage points, on the high side; the range from low to high includes it.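

In this assay, 4-chlorobenzyl to 4-fluorobenzyl on the core of compound 3 came with a number 1.1 percentage points lower from compound 3 to compound 4 (within the scatter). Set beside the same change on the core of compound 1, the two steps do not differ beyond what repeated measurements allow: the same change on two cores in this assay, a number 5.1 percentage points higher (within the scatter) from compound 1 to compound 2 and a number 1.1 percentage points lower (within the scatter) from compound 3 to compound 4, 6.2 percentage points apart, within the scatter of two such steps. So these two pairs give no sign that the core alters the outcome of this change, but with both steps within the scatter they show neither that the change moves the read-out on either core nor that it would behave the same way on a further core.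

The compounds shown leave open whether another group on that aromatic carbon, such as an amine or a carboxylic acid, would give a step beyond the scatter on either core. Also open, going by these compounds, is what each of the places in which the two cores differ contributes on its own.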